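A few compounds are considered here, and "the series" means these few. Any claim that something is new, unique, unknown or untested is made for them only; others in the source may bear on it.

Measured so far in a functional assay (aorta) with Rattus norvegicus as the target; on this read-out lower numbers stand for lower potency and higher numbers for higher potency (the scale is a negative logarithm):
compound 1 `CC1(C)C=C(n2ccccc2=O)c2ccccc2O1`: 5.43
compound 2 `CC(=O)c1ccc2c(c1)C(n1ccccc1=O)=CC(C)(C)O2`: 7.37
compound 3 `CC1(C)C=C(n2ccccc2=O)c2cc(C(=N)NO)ccc2O1`: 5.99

Compound 3 stands second highest of the three numbers. Its nearest neighbour is compound 1, with a number 0.56 log units higher from compound 1 to compound 3 (beyond the scatter); the furthest is compound 2, with a number 1.38 log units lower from compound 2 to compound 3 (beyond the scatter). Compound 4 `CC1(C)C=C(n2ccccc2=O)c2cc(C#N)ccc2O1` differs from compound 3 at a single point: a group of 2 heavy atoms (1 carbon, 1 nitrogen; no ring) in place of a group of 4 heavy atoms (1 carbon, 2 nitrogen, 1 oxygen; no ring), on an aromatic carbon. Both measured steps at this aromatic carbon bear on the change. Starting from hydrogen, a number 1.94 log units higher from compound 1 to compound 2 (beyond the scatter) was large, while a number 0.56 log units higher from compound 1 to compound 3 (beyond the scatter) was modest, so each group placed here has so far raised the number. Going by the values given here, no step involving cyano has been measured, and cyano is a smaller group than either precedent, so the outcome is placed between them. The expected step is a number 0.71 log units higher from compound 3 to compound 4 (beyond the scatter), upward. Compound 4 is estimated at 6.7, with a range of 6 to 7.4.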

Compound 4, logarithm of the reciprocal of the active concentration, log(1/C): 7.67
Beside the measured number, compound 4's estimate is 0.97 log units below it; the measured number lies above the stated range.
By their numbers in this assay, from the lowest: compound 1; then compound 3; then compounds 2 and 4 (each within the scatter of the next).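

On this aromatic carbon, this assay shows a number 2.24 log units higher from compound 1 to compound 4 (beyond the scatter) with cyano in place of hydrogen, so a large rise here does not depend on acetyl. Cyano in place of acetyl gives a number 0.30 log units higher from compound 2 to compound 4 (within the scatter) and leaves the two groups level. Cyano in place of the larger group gives a number 1.68 log units higher from compound 3 to compound 4 (beyond the scatter) and so the modest rise seen with that group belongs to that group, not to the position as a whole.

From the compounds shown here alone, whether an amine, a carboxylic acid or a trifluoromethyl group on this carbon would match cyano remains open. Nothing shown explains these differences.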